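Notes on the oxolane replacement in compound 3

The compounds below may be only part of what the source reports. "The series", "measured", "known", "first", "only" and "open" are said of these compounds alone.

Among the measured compounds shown here, compound 2 `CCN(CC)c1ccc(NC(=O)c2c(-c3c(Cl)cccc3Cl)noc2CCC2OCCO2)cc1` holds the lowest of the two numbers so far in a functional assay on CHO-K cells with growth hormone secretagogue receptor type 1 (Homo sapiens) as the target, read by FLIPR; on this read-out higher numbers stand for weaker inhibition and lower numbers for stronger inhibition: compound 2 gives 56 nM, while compound 1 `CCCc1onc(-c2c(Cl)cccc2Cl)c1C(=O)Nc1ccc(N(CC)CC)cc1` gives 492 nM. Compound 3 `CCN(CC)c1ccc(NC(=O)c2c(-c3c(Cl)cccc3Cl)noc2CCC2CCCO2)cc1` differs from compound 2 by oxolan-2-yl in place of 1,3-dioxolan-2-yl on a saturated chain carbon, two bonds along the chain from an aromatic carbon. For the measured compounds named here, the only measured step at this position is an 8.8-fold lower number from compound 1 to compound 2 (0.94 log units; beyond the scatter); no measured step exchanges one five-membered ring for another of different composition. A shift smaller than that measured one is therefore expected, if any, toward a higher number. For compound 3 the expected step is a 1.5-fold higher number from compound 2 to compound 3 (0.18 log units; within the scatter). Compound 3 is estimated at 85 nM, with a range of 30 nM to 250 nM.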

Compound 3, half-maximal inhibitory concentration: 57 nM
For compound 3 the middle estimate is 1.5-fold (0.17 log units) above the measured one; the measured number falls inside the stated range.
By their numbers in this assay, from the lowest: compounds 2 and 3 (each within the scatter of the next); then compound 1.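

In this assay, oxolan-2-yl and 1,3-dioxolan-2-yl on this saturated chain carbon cannot be told apart, with a 1.0-fold higher number from compound 2 to compound 3 (0.01 log units; within the scatter). The step from methyl at this place is not tied to the 1,3-dioxolan-2-yl group, since the ring with one hetero atom also gives an 8.6-fold lower number from compound 1 to compound 3 (0.94 log units; beyond the scatter). Nothing available explains why the two rings read alike.

The compounds shown leave open whether any ring oxygen is needed at this place, which cyclopentyl would test. They also leave open whether an open-chain ether such as methoxymethyl would hold the same number.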